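The source may report more compounds than this note shows. Statements on the series, on what has been measured and on what is new or still open speak of the compounds shown alone.

Measured so far in a functional assay on MCF cells (Homo sapiens) for antiproliferative activity, with a stated time of 72 h; on this read-out lower numbers stand for stronger inhibition and higher numbers for weaker inhibition:

- Compound 1 `OC[C@H]1O[C@@H](n2cnc3c(NCc4ccccc4Cl)ncnc32)[C@H](O)[C@@H]1O`: > 166000 nM, a limit
- Compound 2 `Cc1ccc(CNc2ncnc3c2ncn3[C@@H]2O[C@H](CO)[C@@H](O)[C@H]2O)cc1`: > 166000 nM, a limit
- Compound 3 `COc1ccc(CNc2ncnc3c2ncn3[C@@H]2O[C@H](CO)[C@@H](O)[C@H]2O)c(OC)c1`: > 166000 nM, a limit

Compound 3 has no exact figure to stand on. In this assay compound 3 gives > 166000 nM, which is a limit and not a number. The whole series looks the same, with the limit of > 166000 nM in this assay, at which 3 of the 3 values shown sit.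

The next compound is compound 4 `OC[C@H]1O[C@@H](n2cnc3c(NCc4ccc(F)cc4Cl)ncnc32)[C@H](O)[C@@H]1O`. It keeps the shared core and differs from compound 3 in one group, on a saturated chain carbon bound to a nitrogen on an aromatic ring: 2-chloro-4-fluorophenyl in place of 2,4-dimethoxyphenyl on a saturated chain carbon bound to a nitrogen on an aromatic ring.

Three measured steps change that same place: a step that the two limits leave unreadable from compound 1 to compound 2, a step that the two limits leave unreadable from compound 1 to compound 3 and a step that the two limits leave unreadable from compound 2 to compound 3. None of them has a readable size, so they offer no measured effect of this group to carry forward. Compound 1 carries 2-chlorophenyl at this place and gives > 166000 nM, again a limit.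

No readable step can therefore be expected in this assay, in either direction, and compound 4 will most likely report a limit too. The expected step is a number no higher from compound 3 to compound 4 (the limit leaves the size open), an estimate with no measured direction behind it. For compound 4 the estimated value is 166000 nM, with an expected range from 70000 nM to 400000 nM.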

Compound 4, half-maximal inhibitory concentration: > 166000 nM
Compound 4: only a limit was reported; the forecaster's own chance of this, stated with the estimate: 85%; the middle value sits exactly at the limit.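

In this assay compound 4 gives > 166000 nM, which is a limit and not a number. Its steps from compound 1, compound 2 and compound 3 therefore cannot be read: the limit of > 166000 nM in this assay, at which 4 of the 4 values shown sit.

The compounds shown leave open what exact value any of them has, and whether changing this group affects the read-out at all.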